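Side chain change from compound 3 to compound 4

The source may report more compounds than this note shows. Statements on the series, on what has been measured and on what is new or still open speak of the compounds shown alone.

Going by the values given here, in a functional assay on Caco-2 cells (Homo sapiens), read by MTT assay, with a stated time of 48 h (a higher number here means a weaker inhibitor, a lower number a stronger inhibitor), compound 3 `CCn1c(C(=O)NCCN)ccc1C(CC)(CC)c1ccc(OCC(O)C(C)(C)C)c(C)c1` stands lowest of the three numbers so far (1000 nM), ahead of compound 1 `CCN(CC)CCNC(=O)c1ccc(C(CC)(CC)c2ccc(OCC(O)C(C)(C)C)c(C)c2)n1CC` (2310 nM) and compound 2 `C#CCNC(=O)c1ccc(C(CC)(CC)c2ccc(OCC(O)C(C)(C)C)c(C)c2)n1CC` (39100 nM). Compound 4 `CCn1c(C(=O)N(C)CCC#N)ccc1C(CC)(CC)c1ccc(OCC(O)C(C)(C)C)c(C)c1` is not yet measured. It carries (2-cyanoethyl)(methyl)amino in place of (2-aminoethyl)amino on a carbonyl carbon.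

Two kinds of measured step bear on this change. Between the two compounds whose chains end in an amino group, the step is modest (a 2.3-fold lower number from compound 1 to compound 3 (0.36 log units; beyond the scatter)). Where compound 2 has ethynyl instead, the steps are large (a 17-fold higher number from compound 1 to compound 2 (1.23 log units; beyond the scatter) and a 39-fold lower number from compound 2 to compound 3 (1.59 log units; beyond the scatter)). The chain of compound 4 also has no amino end, which makes compound 2 the nearest reference. Among the compounds with values here, no measured compound carries the entering group, so the range stays wide.

A large step to a higher number is expected in this assay (a 20-fold higher number from compound 3 to compound 4 (1.30 log units; beyond the scatter)). For compound 4 the estimated value is 20000 nM, with an expected range from 6000 nM to 60000 nM.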

Compound 4, half-maximal inhibitory concentration: > 50000 nM
Compound 4: a limit, no number (the forecaster's own chance of this, stated with the estimate: 15%); at least 2.5-fold (0.39 log units) between middle value and limit.
By their numbers in this assay, from the lowest: compound 3; then compound 1; then compound 2. At a limit, above all of these: compound 4.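

In this assay, compound 4 gives a limit and not a number: the limit of > 50000 nM in this assay, at which 1 of the 4 values shown sits. On the carbonyl carbon, the new chain gives an at least 50-fold higher number from compound 3 to compound 4 (1.69 log units; beyond the scatter) and an at least 21-fold higher number from compound 1 to compound 4 (1.33 log units; beyond the scatter), so both compounds whose chains end in an amino group stand well clear of it, and replacing the terminal amine with a nitrile on a chain of this kind does not preserve their level. Against the propargylamino chain, the step is only a floor, an at least 1.2-fold higher number from compound 2 to compound 4 (0.10 log units; that floor lies within the scatter), which lies within the scatter, so no order can be given for the two chains without an amino end.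

The change adds a methyl on the amide nitrogen and replaces the terminal amine with a nitrile at once, and the compounds shown do not separate these two parts. A (2-aminoethyl)(methyl)amino group would isolate the methyl, and a (2-cyanoethyl)amino group would isolate the nitrile.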